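Swapping the amine on the shared core's side chain

This account rests on a few compounds, and the source may have more. Where it says the series, first, only, none or still open, it means among the compounds named here.

Compound 1 `CCCNCCCCOc1c(O)cc(O)c2c(=O)cc(-c3ccccc3)oc12` carries a propylamino end on its chain, and in a functional assay on A549 cells (Homo sapiens) for cytotoxicity, read by MTT assay, with a stated time of 48 h (on this read-out lower numbers stand for stronger inhibition and higher numbers for weaker inhibition), compound 1 gives "not determined" (no result reported), that is, no single number is reported. Compound 3 `COc1c(O)cc(O)c2c(=O)cc(-c3ccc(Cl)cc3)oc12` in this assay gives "not determined" (no result reported), also without a result, so compound 1 stands beside one further entry lacking a value. For the measured compounds named here, the only measured point is compound 2 `COc1c(OCCCN2CCN(C)CC2)cc(O)c2c(=O)cc(-c3ccccc3)oc12`, which in this assay gives 9900 nM. Compound 4 `CN1CCN(CCCCOc2c(O)cc(O)c3c(=O)cc(-c4ccccc4)oc23)CC1` differs from compound 1 by 4-methylpiperazin-1-yl in place of propylamino on a saturated chain carbon, four bonds along the chain from an oxygen on an aromatic ring. With no number for compound 1, the size and direction of the step in this assay cannot be anchored, and no change beyond the scatter is assumed. Compound 4 is expected to show a value near 10000 nM, between 3000 nM and 35000 nM, because compound 2 gives 9900 nM.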

Compound 4, half-maximal inhibitory concentration: > 100000 nM
Compound 4 was reported as a limit; the forecaster's own chance of this, stated with the estimate: 15%; middle value at least 10-fold (1.00 log units) from the limit.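

No step can be read between compound 1 and compound 4: compound 1 has no single number, and compound 4 is reported only as a limit. The compounds shown leave open how propylamino and 4-methylpiperazin-1-yl compare on this chain.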